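Working notes: fluoro to methyl on the aryl ether

A few compounds are considered here, and "the series" means these few. Any claim that something is new, unique, unknown or untested is made for them only; others in the source may bear on it.

Measured so far:
compound 1, `O=C(O)c1csc([C@H]2CC[C@@H]3[C@@H](COc4ccc(OC(F)(F)F)cc4)[C@H](O)C[C@@H]3O2)n1`, 14 nM
compound 2, `O=C(O)c1csc([C@H]2CC[C@@H]3[C@@H](/C=C/CCCOc4ccccc4)[C@H](O)C[C@@H]3O2)n1`, 13 nM
compound 3, `O=C(O)c1csc([C@H]2CC[C@@H]3[C@@H](COc4cccc(F)c4)[C@H](O)C[C@@H]3O2)n1`, 5.4 nM

All three share the same core and differ only in the side arm that carries the aryl ether. In a functional assay on CHO cells for agonist activity at prostaglandin E2 receptor EP2 subtype (Homo sapiens), read by HTRF and cAMP accumulation, with a stated time of 30 min (on this read-out higher numbers stand for an effect only at larger amounts of compound and lower numbers for an effect already at smaller amounts), compound 3 gives 5.4 nM, the lowest of the three numbers. Compound 2 gives 13 nM and compound 1 gives 14 nM; both gaps to compound 3 lie beyond the usual scatter, so compound 3 stands as the most potent of the measured set. No two of the measured compounds differ in a single place, so no single step can be read off among them.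

Compound 4, `Cc1cccc(OC[C@@H]2[C@H]3CC[C@H](c4nc(C(=O)O)cs4)O[C@H]3C[C@H]2O)c1`, is compound 3 with one change: methyl in place of fluoro on an aromatic carbon. Nothing measured in this set shows what such a swap does. The expected step in this assay is a 1.3-fold higher number from compound 3 to compound 4 (0.11 log units; within the scatter), small and of no firm direction, likely within the scatter. Compound 4 is therefore estimated at about 7 nM, with an expected range from 3 nM to 20 nM.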

Compound 4, half-maximal effective concentration: 3.6 nM
The estimate for compound 4 lay 1.9-fold (0.29 log units) above the measured number; low and high end bracket the measured number.
By their numbers in this assay, from the lowest: compounds 4 and 3 (each within the scatter of the next); then compounds 2 and 1 (each within the scatter of the next).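

In this assay, going from 3-fluorophenoxy to 3-methylphenoxy gives a 1.5-fold lower number from compound 3 to compound 4 (0.18 log units; within the scatter), so fluoro and methyl on this aromatic carbon, meta to a large group, cannot be told apart on this read-out. Going by these compounds alone, this pair is the first to differ in one place, which the earlier compounds could not offer, and it gives a direct reading for this single position. No data at hand bear on why the two groups read alike.

As far as these compounds go, whether chloro, methoxy or nitrile on the same carbon would also read alike remains open. Also open, from the compounds shown here alone, is whether methyl in place of fluoro behaves the same on other carbons of the ring or with a longer chain in the side arm.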